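Acetyl to 2-Hydroxyethyl on the Chain of Compound 2

The compounds below may be only part of what the source reports. "The series", "measured", "known", "first", "only" and "open" are said of these compounds alone.

In a functional assay on the whole organism (stomach) with Rattus norvegicus as the target (on this read-out lower numbers stand for an effect already at smaller amounts and higher numbers for an effect only at larger amounts of compound), compound 1 `CCCCCCCC/N=C/N1CCC(C(c2ccccc2)c2ccccc2)CC1` gives 3.9 mg/kg. Compound 2 `CC(=O)CCCCCC/N=C/N1CCC(C(c2ccccc2)c2ccccc2)CC1` gives 10.5 mg/kg, the higher of the two actual numbers available, and compound 1 is its nearest neighbour on the scale. Compound 3 `CCCCCCCC/N=C/N1CCC(C(c2ccccc2)c2ccc(O)cc2)CC1` is reported at > 40 mg/kg, which is a limit of the assay and not a number.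

Compound 4 `OCCCCCCCC/N=C/N1CCC(C(c2ccccc2)c2ccccc2)CC1` is related to compound 2 by 2-hydroxyethyl in place of acetyl on a saturated chain carbon, six bonds along the chain from a double-bonded nitrogen. Here 2-hydroxyethyl stands in place of acetyl on a saturated chain carbon, six bonds along the chain from a double-bonded nitrogen.

Going by the values given here, two measured steps bear on this change, though neither is the same exchange. Acetyl in place of ethyl at that chain carbon gave a modest step, a 2.7-fold higher number from compound 1 to compound 2 (0.43 log units; beyond the scatter). Hydroxy in place of hydrogen on an aromatic carbon gave a large one, an at least 10-fold higher number from compound 1 to compound 3 (1.01 log units; beyond the scatter). Both steps run towards higher numbers, so a modest move in the same direction is expected here, rather than one as large as the aromatic hydroxy step. The expected size is a 2.1-fold higher number from compound 2 to compound 4 (0.32 log units; beyond the scatter). In this assay, the estimated value for compound 4 is 22 mg/kg, with an expected range from 9 mg/kg to 60 mg/kg.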

Compound 4, dose for half-maximal effect: 8.5 mg/kg
Beside the measured number, compound 4's estimate is 2.6-fold (0.41 log units) above it; measured number below the stated range.
By their numbers in this assay, from the lowest: compound 1; then compounds 4 and 2 (each within the scatter of the next). At a limit, above all of these: compound 3.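

In this assay the exchange of acetyl for 2-hydroxyethyl at this chain carbon gives a 1.2-fold lower number from compound 2 to compound 4 (0.09 log units; within the scatter) and so does not separate the two groups on this read-out, although 2-hydroxyethyl counts a hydrogen-bond donor where acetyl counts none. The step of a 2.2-fold higher number from compound 1 to compound 4 (0.34 log units; beyond the scatter) now stands alongside a 2.7-fold higher number from compound 1 to compound 2 (0.43 log units; beyond the scatter) as a second modest move to a higher number, so an oxygen-bearing group at this end of the chain goes with a higher number than the plain chain of compound 1 in both cases shown. The earlier compounds shown here offered this only for acetyl, while compound 4 shows it for a hydroxy group on a saturated chain carbon as well.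

As far as these compounds go, whether an amine or a carboxylic acid at the end of the chain would stay as close to compound 2, and how a longer chain carrying the same hydroxy group would read, remains open. No measured property of these compounds is given that could account for the exchange leaving the number within the scatter.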